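Moving the ring nitrogen of the amide-linked pyridine

The source may report more compounds than this note shows. Statements on the series, on what has been measured and on what is new or still open speak of the compounds shown alone.

Compound 1 `Cc1c(C)c2c(c(C)c1O)CCC(C)(C(=O)N1CCNCC1)O2` gives 10000 nM in a functional assay (brain) for inhibition, with Rattus norvegicus as the target; on this read-out lower numbers stand for stronger inhibition and higher numbers for weaker inhibition.
Compound 2 `Cc1c(C)c2c(c(C)c1O)CCC(C)(C(=O)NCc1cccnc1)O2` gives 47000 nM in this assay.
Compound 3 `Cc1c(C)c2c(c(C)c1O)CCC(C)(C(=O)Nc1ccncc1)O2` gives 2300 nM in this assay.

Compound 3 holds the lowest number of the three, separated from the others beyond the scatter: a 4.3-fold lower number from compound 1 to compound 3 (0.64 log units; beyond the scatter) and a 20-fold lower number from compound 2 to compound 3 (1.31 log units; beyond the scatter). Compound 4 `Cc1c(C)c2c(c(C)c1O)CCC(C)(C(=O)Nc1ccccn1)O2` keeps every atom of compound 3 and differs only in how they are joined: pyridin-2-yl in place of pyridin-4-yl on an amide-type nitrogen. Among the compounds with values here, no measured step swaps one pyridin-yl for another alone; the nearest guide is a 20-fold lower number from compound 2 to compound 3 (1.31 log units; beyond the scatter), which also removed a methylene, so it offers only loose support. Compound 4 is therefore expected to move only modestly from compound 3 in this assay, in an uncertain direction, a 1.5-fold higher number from compound 3 to compound 4 (0.18 log units; within the scatter). Compound 4 is estimated at 3500 nM, between 1000 nM and 12000 nM.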

Compound 4, half-maximal inhibitory concentration: 1800 nM
Beside the measured number, compound 4's estimate is 1.9-fold (0.29 log units) above it; the measured number falls inside the stated range.
By their numbers in this assay, from the lowest: compounds 4 and 3 (each within the scatter of the next); then compound 1; then compound 2.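

In this assay, the change from pyridin-4-yl to pyridin-2-yl on the amide-type nitrogen stays within the scatter (a 1.3-fold lower number from compound 3 to compound 4 (0.11 log units; within the scatter)), so these two attachments of the ring cannot be told apart on this read-out. The new isomer also stands clear of the other two amides (a 26-fold lower number from compound 2 to compound 4 (1.42 log units; beyond the scatter); a 5.6-fold lower number from compound 1 to compound 4 (0.74 log units; beyond the scatter)), which shows that the gap seen with compound 3 is not confined to pyridin-4-yl. Nothing available explains these steps.

On these data alone, whether pyridin-3-yl on the same nitrogen would fall with compound 3 and compound 4 remains open. So does whether a plain phenyl ring, without the ring nitrogen, would do the same.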